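Arylvinyl ketone series: indole to dichlorophenyl swap

The source may hold more compounds than are shown below. What is called first, only, known or untested is meant among the compounds shown, and "the series" means these compounds.

Measured so far in a functional assay on DU-145 cells (Homo sapiens) for inhibition, read by trypan blue exclusion, with a stated time of 96 h; a lower number here means a stronger inhibitor of growth, a higher number a weaker inhibitor of growth:
- compound 1 `Cc1ccc(CS/C(=C/c2c[nH]c3ccc(Cl)cc23)C(=O)c2ccc(Cl)cc2)cc1` gives 1000 nM
- compound 2 `Cc1ccc(S/C(=C/c2sccc2C)C(=O)c2ccc(Br)cc2)cc1` gives 50000 nM
- compound 3 `Cc1cc(C)cc(/C=C(/Sc2ccc(Br)cc2)C(=O)c2ccc(Cl)cc2)c1` gives 10000 nM

Compound 1 stands at the lowest of the three numbers. Its nearest neighbour is compound 3, which sits higher by a gap beyond the scatter; compound 2 sits further off still, also beyond the scatter. Among the measured compounds shown here, compound 2 and compound 3 differ from compound 1 at several places at once, so no single step between measured compounds can be read from them.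

Compound 4 `Cc1ccc(CS/C(=C/c2cc(Cl)cc(Cl)c2)C(=O)c2ccc(Cl)cc2)cc1` has not yet been measured in this assay. It differs from compound 1 in one place: 3,5-dichlorophenyl in place of 5-chloro-1H-indol-3-yl on a double-bonded chain carbon bound to a double-bonded chain carbon.

For the measured compounds named here, no measured pair isolates this change. What the three numbers show is that the compound carrying the 5-chloro-1H-indol-3-yl group gives the lowest number, while the two compounds carrying plain six-membered carbon rings at that position both give higher numbers. On that basis compound 4 is expected to give a higher number than compound 1, with the step of a 5.0-fold higher number from compound 1 to compound 4 (0.70 log units; beyond the scatter) estimated as clearly beyond the scatter but short of the gap to compound 3, since compound 3 also differs elsewhere. The estimate for compound 4 is 5000 nM, expected within 1500 nM to 20000 nM.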

Compound 4, concentration for 50% growth inhibition: 10000 nM
For compound 4 the middle estimate is 2.0-fold (0.30 log units) below the measured one; measured number inside the range.
By their numbers in this assay, from the lowest: compound 1; then compounds 3 and 4 (each within the scatter of the next); then compound 2.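

In this assay, among the compounds shown here, 3,5-dichlorophenyl in place of 5-chloro-1H-indol-3-yl gives a 10-fold higher number from compound 1 to compound 4 (1.00 log units; beyond the scatter), the only step here that isolates this position with the rest of the molecule held fixed. For the compounds shown here, the position is therefore sensitive to the group it carries, and exchanging this two-ring group with its hydrogen-bond donor for a single carbon-only ring with no donor does not leave the growth-inhibition read-out unchanged, something the earlier compounds, which differ at several places at once, could not show. No measurement here ties the step to any single difference between the two groups.

The compounds shown leave open whether the loss of the ring hydrogen on nitrogen, the loss of the five-membered ring or the change in chlorine substitution accounts for the step; an indole bearing a methyl group on that nitrogen and an unsubstituted indol-3-yl group would begin to separate these. From the compounds shown here alone, it also remains open whether the same step would appear with a different sulfur substituent in place of the one shared by these two compounds.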